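Trifluoromethyl in place of hydrogen: compound 1 to compound 3

A few compounds are considered here, and "the series" means these few. Any claim that something is new, unique, unknown or untested is made for them only; others in the source may bear on it.

Of the compounds shown here, two have been measured in a functional assay on HCT-116 cells (Homo sapiens) for antiproliferative activity, read by MTT assay, with a stated time of 72 h; on this read-out lower numbers stand for stronger inhibition and higher numbers for weaker inhibition. Compound 1 `O=C(CSc1cccc(O)c1)Nc1ccc2nc(NC(=O)c3ccccc3)sc2c1` gives 41000 nM, the lowest of the two numbers; compound 2 `Cc1cc(C)cc(C(=O)Nc2nc3ccc(NC(=O)CSc4ccc(Cl)cc4)cc3s2)c1` gives 65100 nM, and the gap between the two lies within the scatter, so neither can be set apart from the other. Both numbers sit in the weak range of this assay.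

Compound 3 `O=C(CSc1cccc(O)c1)Nc1ccc2nc(NC(=O)c3ccc(C(F)(F)F)cc3)sc2c1` is the next entry. It differs from compound 1 in one place: trifluoromethyl in place of hydrogen on an aromatic carbon. Cut one bond further out, the change reads phenyl to 4-(trifluoromethyl)phenyl. Going by the values given here, no measured pair isolates this change, so nothing in the data sizes it. The step from compound 1 to compound 3 is expected to be a 1.3-fold lower number from compound 1 to compound 3 (0.11 log units; within the scatter), a shift not clearly beyond the scatter in either direction. Compound 3 is therefore estimated at 32000 nM in this assay, with a range from 10000 nM to 100000 nM.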

Compound 3, half-maximal inhibitory concentration: 510 nM
Estimate against measurement, compound 3: 63-fold (1.80 log units) above; the whole stated range lies above it.
By their numbers in this assay, from the lowest: compound 3; then compounds 1 and 2 (each within the scatter of the next).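

In this assay, trifluoromethyl in place of hydrogen on the aromatic carbon para to a large group gives an 80-fold lower number from compound 1 to compound 3 (1.91 log units; beyond the scatter), a large step beyond the scatter. Going by these compounds alone, compounds 1 and 2 differ in more than one place and gave no reading of this position, which now proves highly responsive to substitution: phenyl to 4-(trifluoromethyl)phenyl is the only change between compound 1 and compound 3. Nothing at hand accounts for the size of the step.

As far as these compounds go, whether the step belongs to trifluoromethyl itself or would also follow from another group on the same carbon, such as a chlorine, a methoxy or a nitrile, remains open. Also open, from the compounds shown here alone, is whether the same change would carry the same weight on a compound with a different group on the sulfur, as in compound 2.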